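Swapping a nitrophenyl for a propoxyphenyl on the chalcone

The source may hold more compounds than are shown below. What is called first, only, known or untested is meant among the compounds shown, and "the series" means these compounds.

Measured so far:
compound 1 `COC(=O)c1cc(-c2cccc(NC(=O)c3ccc(/C=C/C(=O)c4cccc([N+](=O)[O-])c4)cc3)c2)on1`: > 40 ug/mL
compound 2 `COC(=O)c1cc(-c2cccc(NC(=O)c3ccc(/C=C/C(=O)c4ccc(OC)cc4OC)cc3)c2)on1`: > 50 ug/mL

Of the compounds shown here, two sharing the same core have been tested in an ADME assay on Vero cells (Chlorocebus sabaeus) for cytotoxicity, read by MTT assay, with a stated time of 72 h; on this read-out lower numbers stand for higher toxicity in this test and higher numbers for lower toxicity in this test. For compound 1 the value is only a limit, so no exact number is known. For compound 2 the value is likewise a limit. For the measured compounds named here, the one comparison available is a step that the two limits leave unreadable from compound 1 to compound 2; both ends sit at limits, as the limit of > 40 ug/mL in this assay, at which 1 of the 2 values shown sits, and the limit of > 50 ug/mL in this assay, at which 1 of the 2 values shown sits, show, so the size of that step cannot be read.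

Compound 3 `CCCOc1ccc(C(=O)/C=C/c2ccc(C(=O)Nc3cccc(-c4cc(C(=O)OC)no4)c3)cc2)cc1` is not yet measured. It differs from compound 1 as follows: 4-propoxyphenyl in place of 3-nitrophenyl on a carbonyl carbon. Going by the values given here, the only measured step, which concerns a different replacement at the same place, gives no readable size, so it offers no guide to direction beyond saying that neither measured compound showed toxicity within the tested range. For compound 3 the expected result is 50 ug/mL, within 30 ug/mL to 100 ug/mL. The expected step is a step that the limit leaves unreadable from compound 1 to compound 3, most likely reported as a limit again.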

Compound 3, half-maximal cytotoxic concentration: > 40 ug/mL
Compound 3 ended at the assay's limit; the forecaster's own chance of this, stated with the estimate: 75%; the middle value lies beyond the limit too.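

The results for compound 1, compound 2 and compound 3 in this assay are all limits and not exact numbers, so no step among these three compounds can be read: the limit of > 40 ug/mL in this assay, at which 2 of the 3 values shown sit. As far as these compounds go, it remains open whether 3-nitrophenyl, 2,4-dimethoxyphenyl or 4-propoxyphenyl on the carbonyl carbon gives any difference in toxicity in this assay.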